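Oral Exposure in Rats: One Pyridyl Swap on a Shared Core

The source may hold more compounds than are shown below. What is called first, only, known or untested is meant among the compounds shown, and "the series" means these compounds.

Measured compounds:
compound 1 `Cc1cn2c(-c3cn[nH]c3)cnc2c(Nc2cc(Cc3ccncc3)ns2)n1` — "not determined" (no result reported)
compound 2 `Cc1ccc(Cc2cc(Nc3nc(C)cn4c(-c5cn[nH]c5)cnc34)sn2)nc1` — 1370 ng.h/mL

In an ADME assay on the whole organism for pharmacokinetics, with Rattus norvegicus as the target, with a stated time of 6 h, at a dose of 10 mg/kg by the oral route (on this read-out higher numbers stand for higher exposure at the dose given and lower numbers for lower exposure), compound 2 gives 1370 ng.h/mL. Compound 1 carries the same core with a pyridin-4-ylmethyl group in the corresponding position, and for compound 1 the entry in this assay reads "not determined" (no result reported), so compound 2 holds the only number shown here, and it stands alone.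

Compound 3 `Cc1cn2c(-c3cn[nH]c3)cnc2c(Nc2cc(Cc3ncccc3F)ns2)n1` is the next compound to be measured. It differs from compound 2 in one place: 3-fluoropyridin-2-yl in place of 5-methylpyridin-2-yl on a saturated chain carbon bound to an aromatic carbon. Among the compounds with values here, no measured pair shows how such a change moves exposure, so nothing in these data points in one direction or the other.

With only compound 2 as a reference, the step is expected to be small, no larger than the usual scatter, and compound 3 is estimated at 1000 ng.h/mL, with a range of 300 ng.h/mL to 3500 ng.h/mL; the expected step of a 1.4-fold lower number from compound 2 to compound 3 (0.14 log units; within the scatter) is modest.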

Compound 3, area under the concentration-time curve: 569 ng.h/mL
Estimate against measurement, compound 3: 1.8-fold (0.24 log units) above, within the range that was stated.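

In this assay the change from (5-methylpyridin-2-yl)methyl to (3-fluoropyridin-2-yl)methyl gives a 2.4-fold lower number from compound 2 to compound 3 (0.38 log units; beyond the scatter) and so shows that exposure responds to what the pyridine ring at this position carries. The two groups match in heavy atoms, in hydrogen-bond donors and acceptors and in having one six-membered aromatic ring with 1 hetero atom, so a swap that leaves these counts unchanged still moved the number beyond the scatter. Nothing measured here bears on what lies behind this step.

Within the data shown here, the single swap removes a methyl group and adds a fluorine together, so the share of each stays unknown, and steps to compound 1 cannot be read. As far as these compounds go, whether a methoxy group or an amine on the same pyridine ring would bring exposure closer to that of compound 2 or of compound 3 also remains open.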